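From compound 2 to a 4-hydroxypiperidin-1-yl analogue

The source may hold more compounds than are shown below. What is called first, only, known or untested is meant among the compounds shown, and "the series" means these compounds.

Measured in a functional assay on MCF7 cells (Homo sapiens) for inhibition, read by resazurin assay, with a stated time of 24 h; on this read-out higher numbers stand for weaker inhibition and lower numbers for stronger inhibition:
- compound 1 `O=C1Nc2c(C(F)(F)F)cccc2C1(c1ccc(O)cc1)N1CCC(F)(F)CC1`: 35 nM
- compound 2 `CC1CN(C2(c3ccc(O)cc3)C(=O)Nc3c(C(F)(F)F)cccc32)CCC1(F)F`: 70 nM

Among the measured compounds shown here, compound 2 sits within the scatter of compound 1, its only neighbour, with a 2.0-fold higher number from compound 1 to compound 2 (0.30 log units; within the scatter). That step is a methyl in place of hydrogen on a saturated ring carbon. Compound 3 `O=C1Nc2c(C(F)(F)F)cccc2C1(c1ccc(O)cc1)N1CCC(O)CC1` remains unmeasured and carries a group of 7 heavy atoms (5 carbon, 1 nitrogen, 1 oxygen; one six-membered non-aromatic ring with 1 hetero atom) in place of a group of 9 heavy atoms (6 carbon, 1 nitrogen, 2 fluorine; one six-membered non-aromatic ring with 1 hetero atom), on a saturated ring carbon. For the measured compounds named here, the methyl step bears only loosely on this exchange, and no measured step covers it directly. A moderate move to a higher number in this assay is expected, with wide uncertainty. The estimated step is a 2.0-fold higher number from compound 2 to compound 3 (0.30 log units; within the scatter). Compound 3 is estimated at 140 nM, with an expected range of 40 nM to 500 nM.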

Compound 3, half-maximal inhibitory concentration: > 1000000 nM
Compound 3 gave a limit, no number; the forecaster's own chance of this, stated with the estimate: 3%; middle value at least 7100-fold (3.85 log units) away from the limit.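

In this assay compound 3 gives a limit, not a number: the limit of > 1000000 nM in this assay, at which 1 of the 3 values shown sits. Placing 4-hydroxypiperidin-1-yl where compound 1 carries 4,4-difluoropiperidin-1-yl gives an at least 28000-fold higher number from compound 1 to compound 3 (4.45 log units; beyond the scatter), and the exchange from the methylated ring gives an at least 14000-fold higher number from compound 2 to compound 3 (4.15 log units; beyond the scatter). Whereas the methyl step stayed within the scatter, these steps show that the group at this place can decide whether a measurable number is obtained at all.

The compounds shown leave open whether a 4-methoxypiperidin-1-yl or a 4-aminopiperidin-1-yl group here would behave like the hydroxy compound or like the difluoro compounds.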